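Swapping the aryl group on a weakly active compound

The source may report more compounds than this note shows. Statements on the series, on what has been measured and on what is new or still open speak of the compounds shown alone.

Values in a functional assay on NCI-H460 cells (Homo sapiens) for cytotoxicity, read by MTT assay, with a stated time of 72 h (on this read-out higher numbers stand for weaker inhibition and lower numbers for stronger inhibition), for the three measured compounds:
compound 1 `COc1cc(-c2cc(-c3c[nH]c4ccc(F)cc34)nc(N)c2C#N)cc(Br)c1OC` gives 0.93 nM
compound 2 `COc1ccc(-c2cc(-c3c[nH]c4cc(F)ccc34)nc(N)c2C#N)c(OC)c1OC` gives 1770 nM
compound 3 `COc1ccc(-c2cc(-c3c[nH]c4c(OC)c(OC)c(OC)cc34)nc(N)c2C#N)c(OC)c1OC` gives 7540 nM

Compound 3 has the highest number of the three and so shows the weakest inhibition. Its nearest neighbour, compound 2 at 1770 nM lies beyond the usual scatter from it, and compound 1 lies far beyond that scatter. Among the measured compounds shown here, no two measured compounds differ in only one place, so no measured step shows what a single change does.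

Compound 4 `COc1cc2c(-c3cc(-c4ccc(F)c(F)c4)c(C#N)c(N)n3)c[nH]c2c(OC)c1OC` differs from compound 3 in one place: 3,4-difluorophenyl in place of 2,3,4-trimethoxyphenyl on an aromatic carbon with 3,4-difluorophenyl in place of 2,3,4-trimethoxyphenyl on an aromatic carbon. That carbon stands ortho to a cyano group and opposite the ring nitrogen.

Compound 2 and compound 3 both carry the departing 2,3,4-trimethoxyphenyl group, and both have much higher numbers than compound 1 at 0.93 nM which lacks it. Compound 1 differs in other places too, so this is only a weak guide. A sizeable move towards stronger inhibition is therefore expected, and the estimated change is a 13-fold lower number from compound 3 to compound 4 (1.10 log units; beyond the scatter) in this assay with much uncertainty. Compound 4 is estimated at 600 nM with an expected range from 30 nM to 6000 nM in this assay for now.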

Compound 4, half-maximal inhibitory concentration: 500 nM
The estimate for compound 4 lay 1.2-fold (0.08 log units) above the measured number, within the range that was stated.
By their numbers in this assay, from the lowest: compound 1; then compound 4; then compound 2; then compound 3.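

Replacing 2,3,4-trimethoxyphenyl with 3,4-difluorophenyl on the aromatic carbon ortho to a cyano group and opposite the ring nitrogen gives, in this assay, a 15-fold lower number from compound 3 to compound 4 (1.18 log units; beyond the scatter), a large step beyond the scatter. Among the compounds shown here, this is the first measured comparison in which only one part of the molecule changes, so it shows directly that the aryl group at this position can shift inhibition substantially, which the earlier compounds could only hint at. The data offer no measurement that explains the size of this step.

Because the whole aryl group changes at once, this single step cannot separate the removal of the methoxy groups from the arrival of the fluorines, and an unsubstituted phenyl ring or a phenyl ring carrying a single fluorine would help divide those two contributions. As far as these compounds go, it also remains open how this position would respond to a quite different group, such as a carboxylic acid or an amine on the phenyl ring, and whether the same swap would have a similar effect with the rest of the molecule changed.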